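The compounds below may be only part of what the source reports. "The series", "measured", "known", "first", "only" and "open" are said of these compounds alone.

Measured so far in an assay on isolated protein for inhibition of polyamine deacetylase HDAC10 (Homo sapiens); a higher number here means a weaker inhibitor, a lower number a stronger inhibitor:
compound 1, `COc1ccc(C(=O)c2ccc3c(ccn3Cc3ccc(C(=O)NO)cc3)c2)cc1`, gives 59800 nM.
Compound 3, `COc1ccc(C(=O)c2ccc3c(ccn3Cc3ccc(/C=C/C(=O)NO)cc3)c2)cc1`, gives 7050 nM.
Compound 2, `COc1cc(C(=O)c2ccc3c(ccn3S(=O)(=O)c3cccc(/C=C/C(=O)NO)c3)c2)cc(OC)c1OC`, yields only a limit, > 100000 nM.

Compound 1 holds the highest of the two numbers; its nearest neighbour is compound 3, reached through an 8.5-fold lower number from compound 1 to compound 3 (0.93 log units; beyond the scatter). Compound 2 stands at the limit of > 100000 nM in this assay, at which 1 of the 3 values shown sits.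

Compound 4, `COc1cccc(C(=O)c2ccc3c(ccn3Cc3ccc(C(=O)NO)cc3)c2)c1`, is not yet measured in this assay and differs from compound 1 by 3-methoxyphenyl in place of 4-methoxyphenyl on a carbonyl carbon. No measured step covers this change: the one step shown alters the hydroxamate-bearing side instead. With nothing comparable to lean on, the move is expected to stay within the scatter, a 1.0-fold higher number from compound 1 to compound 4 (0.00 log units; within the scatter). Compound 4 is therefore estimated at 60000 nM in this assay, between 25000 nM and 150000 nM.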

Compound 4, half-maximal inhibitory concentration: 47900 nM
For compound 4 the middle estimate is 1.3-fold (0.10 log units) above the measured one; the measured number falls inside the stated range.
By their numbers in this assay, from the lowest: compound 3; then compounds 4 and 1 (each within the scatter of the next). At a limit, above all of these: compound 2.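

This is the first variation shown on the aryl ketone side of the molecule. In this assay, placing 3-methoxyphenyl where 4-methoxyphenyl stood on a carbonyl carbon gives a 1.2-fold lower number from compound 1 to compound 4 (0.10 log units; within the scatter), so the two compounds cannot be told apart, whereas the earlier hydroxycarbamoyl to 2-(hydroxycarbamoyl)ethenyl step lay beyond the scatter. Nothing measured here accounts for this result.

Still open, on these data alone, is how 2-methoxyphenyl, hydroxyphenyl or aminophenyl would behave on this carbonyl. Also open, as far as these compounds go, is whether 3-methoxyphenyl would match 4-methoxyphenyl alongside the 2-(hydroxycarbamoyl)ethenyl group of compound 3.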